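The source may report more compounds than this note shows. Statements on the series, on what has been measured and on what is new or still open speak of the compounds shown alone.

The study turns on a small set of triaryl carbinol-type compounds tested in a functional assay on NIH3T3 cells (Mus musculus) for antiproliferative activity; on this read-out lower numbers stand for stronger inhibition and higher numbers for weaker inhibition. Compound 1 `OC(c1ccccc1)(c1ccccc1)c1ccccc1Cl` is the anchor: in this assay compound 1 gives 2100 nM, the only single number shown for it, with one further entry that is not a single number. Compound 2 `Oc1ccccc1C(O)(c1ccccc1)c1ccccc1` was measured more than once, and in this assay compound 2 gives 800 nM; 3300 nM (2 entries). The spread between those repeats, (the several entries of compound 2 in this assay, 800 nM; 3300 nM (2 entries)), shows how far two readings of one compound can sit apart, so single values carry real uncertainty. Among the measured compounds shown here, no two measured compounds here differ in a single place, so no measured step can be read off directly.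

Compound 3 `O=C(O)CC(c1ccccc1)(c1ccccc1)c1ccccc1Cl` has not yet been tested. Its difference from compound 1 is carboxymethyl in place of hydroxy on a saturated chain carbon bound to three aromatic carbons. For this change the account expects a step from compound 1 to compound 3 that goes towards weaker inhibition and falls beyond the usual scatter, though not far. Compound 3 is therefore estimated at 4500 nM, within a range from 1200 nM to 17000 nM, corresponding to an expected step of a 2.1-fold higher number from compound 1 to compound 3 (0.33 log units; beyond the scatter).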

Compound 3, half-maximal inhibitory concentration: 1200 nM
The estimate for compound 3 lay 3.8-fold (0.57 log units) above the measured number; the measured number falls inside the stated range.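

On this carbon, the saturated chain carbon bound to three aromatic carbons, carboxymethyl in place of hydroxy gives a 1.8-fold lower number from compound 1 to compound 3 (0.24 log units; within the scatter) in this assay, so the two compounds cannot be told apart on this read-out. Among the compounds shown here, this is the first direct reading of any single change, and it shows that, for this pair, the hydroxy is not required to keep inhibition in the range of compound 1, even though a larger group stands in its place. The pair supports no ranking of the two groups, and the repeated readings of a related compound show how loosely single values sit in this assay: the several entries of compound 2 in this assay, 800 nM; 3300 nM (2 entries)

This is one change on one core, so it cannot show whether the same holds for other groups on this carbon, such as an amine, a carboxylic acid bound directly to it, or a longer chain ending in a carboxylic acid. The compounds shown also leave open whether the result depends on the chlorine that compound 1 and compound 3 share.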